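Swapping Phenyl for Methyl on a Tetrazole Sulfide

A few compounds are considered here, and "the series" means these few. Any claim that something is new, unique, unknown or untested is made for them only; others in the source may bear on it.

Compound 1 `Cn1nnnc1SCC(=O)N/N=c1/scc(-c2ccc(F)cc2)n1-c1ccccc1` gives "not determined" (no result reported) in a functional assay on C6 cells (Rattus norvegicus) for cytotoxicity, read by MTT assay, with a stated time of 24 h; a higher number here means a weaker inhibitor, a lower number a stronger inhibitor.
Compound 2 `O=C(CSc1nnnn1-c1ccccc1)N/N=c1/scc(-c2ccccc2)n1-c1ccccc1` gives 8.3 ug/mL in this assay.

For the measured compounds named here, compound 2 holds the only number here, so it cannot be ranked against anything else. Compound 3 `Cn1nnnc1SCC(=O)N/N=c1/scc(-c2ccccc2)n1-c1ccccc1` differs from it by methyl in place of phenyl on an aromatic nitrogen. Going by the values given here, no measured pair shows this kind of change, so the size of the step is open. The step of a 1.4-fold higher number from compound 2 to compound 3 (0.16 log units; within the scatter) is expected to be small, leaning toward a weaker inhibitor, and may not exceed the scatter. Compound 3 is expected to give about 12 ug/mL in this assay, within 5 ug/mL to 30 ug/mL.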

Compound 3, half-maximal inhibitory concentration: 67.7 ug/mL
Estimate against measurement, compound 3: 5.6-fold (0.75 log units) below, outside the stated range (above it).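

Going from 1-phenyl-1H-tetrazol-5-yl to 1-methyl-1H-tetrazol-5-yl gives an 8.2-fold higher number from compound 2 to compound 3 (0.91 log units; beyond the scatter) in this assay. This group on the aromatic nitrogen therefore matters in this assay, and in this pair phenyl gives the stronger inhibitor. No measurement here shows what lies behind the difference.

This single pair leaves open whether a longer chain such as ethyl or a benzyl group on this nitrogen would fall between the two values. It also cannot show whether the same change would have a similar effect on another core.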